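Benzyl ether in place of the phenol of compound 3

A few compounds are considered here, and "the series" means these few. Any claim that something is new, unique, unknown or untested is made for them only; others in the source may bear on it.

Compound 3 `COc1cc2ncn(-c3cc(O)c(C#N)s3)c2cc1OC` carries a free hydroxyl and a nitrile on the ring joined to the shared core. In an assay on isolated protein for inhibition of inhibitor of nuclear factor kappa-B kinase subunit epsilon (Homo sapiens), read by TR-FRET (a lower number here means a stronger inhibitor, a higher number a weaker inhibitor), compound 3 gives 2510 nM, the higher of the two numbers in hand. Compound 2 `COc1cc2c(cc1OCCCO)ncn2-c1cc(OCc2ccccc2C(F)(F)F)c(C#N)s1`, which bears a trifluoromethyl-substituted benzyl ether on that oxygen and a hydroxypropoxy chain on the core in place of one methoxy, gives 25.1 nM in this assay, a gap that lies well beyond the scatter. Compound 1 `COc1cc2ncn(-c3cc(OCC4CCCO4)c(C(N)=O)s3)c2cc1OC`, with a carboxamide and a tetrahydrofuranylmethyl ether, is reported in this assay only as a limit, < 15900 nM. This limit, (the limit of < 15900 nM in this assay, at which 1 of the 3 values shown sits), supplies no number.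

Compound 4 `COc1cc2ncn(-c3cc(OCc4ccc(C(N)=O)cc4)c(C#N)s3)c2cc1OC` differs from compound 3 by 4-carbamoylbenzyl in place of hydrogen on an oxygen on an aromatic ring. For the measured compounds named here, no measured pair differs in this single place, so the expectation rests on what compound 2 shows: with an aryl-methyl ether on the same oxygen, together with a changed core, compound 2 gives 25.1 nM, whereas compound 3 gives 2510 nM. The step from compound 3 to compound 4 in this assay is expected to move towards a lower number, beyond the scatter, as a 21-fold lower number from compound 3 to compound 4 (1.32 log units; beyond the scatter). Compound 4 is estimated at 120 nM in this assay, within a range from 25 nM to 600 nM.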

Compound 4, half-maximal inhibitory concentration: 12600 nM
Compound 4: middle estimate off by 110-fold (2.02 log units), on the low side, and the stated range ends below it.
By their numbers in this assay, from the lowest: compound 2; then compound 3; then compound 4.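

In this assay, for the compounds shown here, putting 4-carbamoylbenzyl in place of hydrogen on an oxygen on an aromatic ring gives a 5.0-fold higher number from compound 3 to compound 4 (0.70 log units; beyond the scatter), the first reading of a change at this oxygen alone, and the step is modest but beyond the scatter. An aryl-methyl ether on this oxygen therefore does not by itself bring a lower number, so the low value of compound 2 cannot be read as a general benefit of etherifying the hydroxyl, since compound 2 differs from compound 4 in more than one place. No measurement shown accounts for the direction of this step.

Open, from the compounds shown here alone, is which feature of compound 2 carries its value, the trifluoromethyl-substituted benzyl or the hydroxypropoxy chain on the core, as each has yet to be read alone against the dimethoxy core with the nitrile kept. Also open, going by these compounds, is how this oxygen responds to an unsubstituted benzyl, or to a benzyl carrying an amine or a carboxylic acid in place of the carbamoyl group.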